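This account rests on a few compounds, and the source may have more. Where it says the series, first, only, none or still open, it means among the compounds named here.

Compound 1, with the structure `CC[C@H]1OC(=O)[C@H](C)[C@@H](O[C@H]2C[C@@](C)(OC)[C@@H](OCCCNC(=O)COC)[C@H](C)O2)[C@H](C)[C@@H](O[C@@H]2O[C@H](C)C[C@H](N(C)C)[C@H]2O)[C@](C)(O)C[C@@H](C)CN(C)[C@H](C)[C@@H](O)[C@]1(C)O`, is the starting point of this comparison. In a physicochemical assay for lipophilicity, read by HPLC, measured as chromatographic lipophilicity, at pH 7.4 (on this read-out lower numbers stand for lower lipophilicity and higher numbers for higher lipophilicity), compound 1 gives 2.16, the lowest of the three numbers gathered so far. The nearest of the others is compound 2, built as `CC[C@H]1OC(=O)[C@H](C)[C@@H](O[C@H]2C[C@@](C)(OC)[C@@H](O)[C@H](C)O2)[C@H](C)[C@@H](O[C@@H]2O[C@H](C)C[C@H](N(C)CCCNC(C)=O)[C@H]2O)[C@](C)(OC)C[C@@H](C)C(=O)[C@H](C)[C@@H](O)[C@]1(C)O`, which in this assay gives 3.08, a number that stands higher than that of compound 1 by more than the usual scatter. Furthest away is compound 3, with the structure `CC[C@H]1OC(=O)[C@H](C)[C@@H](O[C@H]2C[C@@](C)(OC)[C@@H](O)[C@H](C)O2)[C@H](C)[C@@H](O[C@@H]2O[C@H](C)C[C@H](N(C)C)[C@H]2O)[C@](C)(O)C[C@@H](C)CN(C)[C@H](C)[C@@H](OCCCNC(=O)C2CCC2)[C@]1(C)O`, which in this assay gives 3.5, again higher than compound 1 by more than the scatter.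

The unmeasured compound 4 has the structure `CCCCCCCC(=O)NCCCO[C@H]1[C@H](C)O[C@@H](O[C@H]2[C@H](C)[C@@H](O[C@@H]3O[C@H](C)C[C@H](N(C)C)[C@H]3O)[C@](C)(O)C[C@@H](C)CN(C)[C@H](C)[C@@H](O)[C@](C)(O)[C@@H](CC)OC(=O)[C@@H]2C)C[C@@]1(C)OC`. Set against compound 1 it shows a single change, counted as hexyl in place of methoxy on a saturated chain carbon bound to a carbonyl carbon. Among the compounds with values here, no step between measured compounds of this set has been worked out, so what follows rests on the change alone and on where compound 1 sits.

A change of this kind is expected to move the number upward, beyond the scatter, so that the step from compound 1 to compound 4 in this assay is estimated at a number 2.14 log units higher from compound 1 to compound 4 (beyond the scatter). For compound 4 the expected value in this assay is therefore 4.3, with a likely range from 3.6 to 5.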

Compound 4, distribution coefficient: 4.1
Compound 4: the middle estimate sits 0.20 log units above what was measured; measured number inside the range.
By their numbers in this assay, from the lowest: compound 1; then compound 2; then compound 3; then compound 4.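

Within the data shown here, compound 1 and compound 4 form the first pair in this set that differs in only one place, so the earlier compounds could not show what a change at this position does on its own. With hexyl in place of methoxy on a saturated chain carbon bound to a carbonyl carbon, and the rest of the structure unchanged, the reading in this assay comes out at a number 1.94 log units higher from compound 1 to compound 4 (beyond the scatter), which shows that this position is far from silent in this assay and that this single change is enough to produce a large step. No measurement shown here explains why the number moves this far at this place.

From the compounds shown here alone, this one pair cannot separate the removal of methoxy, with its hydrogen-bond acceptor, from the arrival of the longer all-carbon hexyl chain, so how much each contributes remains open. Also open, going by these compounds, is how the number would respond at the same place to a shorter chain such as propyl, a longer chain such as decyl, or a chain ending in an amine or a carboxylic acid.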